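The source may report more compounds than this note shows. Statements on the series, on what has been measured and on what is new or still open speak of the compounds shown alone.

The three measured compounds, each in a functional assay on HCC1806 cells (Homo sapiens) for inhibition, read by sulforhodamine B assay, tested at 10 uM; on this read-out higher numbers stand for more inhibition at the one concentration tested (going by the name of the read-out) and lower numbers for less inhibition:

compound 1, `CN(C)c1ccc(C2CC(c3ccc(-n4cncn4)cc3)=NN2)cc1`: 6.8%
compound 2, `CC(=O)N1N=C(c2ccc(-n3cncn3)cc2)CC1c1ccc(N(C)C)cc1`: 11%
compound 3, `CN(C)c1ccc(C2CC(c3ccc(-n4cncn4)cc3)=NN2C(=O)c2ccc(F)cc2)cc1`: 15.6%

Compound 3 gives the largest of the three numbers, but it is not separated from the others: the step of a number 4.6 percentage points higher from compound 2 to compound 3 (within the scatter) and the step of a number 8.8 percentage points higher from compound 1 to compound 3 (within the scatter) both lie within the scatter, as does a number 4.2 percentage points higher from compound 1 to compound 2 (within the scatter). The three compounds are therefore indistinguishable on this read-out.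

Compound 4 is `CN(C)c1ccc(C2CC(c3ccc(-n4cncn4)cc3)=NN2C(=O)c2ccc(C(F)(F)F)cc2)cc1`. It differs from compound 3 in one place: trifluoromethyl in place of fluoro on an aromatic carbon.

Among the compounds with values here, no measured step alters a substituent on this aromatic ring, so none bears on the change directly. The closest comparison is the step from the acetyl compound to the benzoyl compound, a number 4.6 percentage points higher from compound 2 to compound 3 (within the scatter), which moved the number only within the scatter, and the other two steps did the same. Within the data shown here, nothing among the measured compounds suggests that a change at this part of the molecule would be any larger.

Compound 4 is therefore expected to show a step of a number 1.4 percentage points higher from compound 3 to compound 4 (within the scatter), that is, no change beyond the scatter. The estimated value of compound 4 in this assay is 17%, within a range of 4% to 32%.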

Compound 4, a percentage reported as inhibition, at one concentration (the size of the read-out at that concentration, not a potency): 7%
Compound 4: the middle estimate sits 10 percentage points above what was measured; low and high end bracket the measured number.
By their numbers in this assay, from the lowest: compounds 1, 4, 2 and 3 (each within the scatter of the next).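

In this assay, the change on the aromatic carbon para to a large group, a number 8.6 percentage points lower from compound 3 to compound 4 (within the scatter), lies within the scatter, so trifluoromethyl in place of fluoro does not separate the two compounds at this position. The wider comparisons read the same way: replacing the methyl on the carbonyl carbon with 4-(trifluoromethyl)phenyl gives a number 4 percentage points lower from compound 2 to compound 4 (within the scatter), and placing (4-(trifluoromethyl)phenyl)carbonyl on the ring nitrogen in place of hydrogen gives a number 0.2 percentage points higher from compound 1 to compound 4 (within the scatter), so both also remain within the scatter and the four compounds cannot be told apart on this read-out. No supporting measurement helps to interpret this result.

From the compounds shown here alone, it remains open whether an amine, a carboxylic acid or a methoxy group on this aromatic carbon, or a longer chain on the carbonyl carbon in place of the aromatic ring, would move the number beyond the scatter. The compounds shown also leave open how any of them would behave across a range of concentrations, since this read-out reports only the one concentration tested.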